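The source may report more compounds than this note shows. Statements on the series, on what has been measured and on what is new or still open speak of the compounds shown alone.

Measured so far:
compound 1, `CCOC(=O)C(CCCCCN)CSC(C)=O`, in an assay on isolated protein for inhibition of carboxypeptidase B (Sus scrofa), read by spectrophotometry, with stated times of 10 min and 30 min; a lower number here means a stronger inhibitor, a higher number a weaker inhibitor: 19000 nM
compound 2, `CCOC(=O)C(C[Se]C(=O)CC)Cc1cnc(N)c(Cl)c1`, in this assay: > 3800000 nM

For the measured compounds named here, compound 1 holds the only numerical value in this assay; the remaining entry is a limit (the limit of > 3800000 nM in this assay, at which 1 of the 2 values shown sits). For compound 2 the result is a limit of the assay and not a number. Going by the values given here, compound 2 differs from compound 1 in more than one place, so no single step between the two is drawn.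

Compound 3, `CCOC(=O)C(CCCCCN)C[Se]C(=O)CC`, is not yet measured. It differs from compound 1 by a group of 5 heavy atoms (3 carbon, 1 oxygen, 1 selenium; no ring) in place of a group of 4 heavy atoms (2 carbon, 1 oxygen, 1 sulfur; no ring), on a saturated chain carbon, two bonds along the chain from a carbonyl carbon. The expected step of a 2.1-fold higher number from compound 1 to compound 3 (0.32 log units; beyond the scatter) is modest, leaning toward a weaker inhibitor, with a wide range since the only other selenium-bearing entry, compound 2, sits at the limit of > 3800000 nM in this assay, at which 1 of the 2 values shown sits, while also differing elsewhere. Compound 3 is expected at 40000 nM, between 8000 nM and 300000 nM.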

Compound 3, half-maximal inhibitory concentration: 910000 nM
Beside the measured number, compound 3's estimate is 23-fold (1.36 log units) below it; the whole stated range lies below it.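

In this assay, the position on a saturated chain carbon, two bonds along the chain from a carbonyl carbon, proves sensitive: exchanging acetylsulfanyl for the selenium-bearing group of 5 heavy atoms gives a 48-fold higher number from compound 1 to compound 3 (1.68 log units; beyond the scatter). For the compounds shown here, this is the only step that can be read, and with the rest of the structure held fixed, the large weakening belongs to this one change. Compound 2, which carries the same selenium-bearing group on a different remainder, gives a limit of the assay and not a number: the limit of > 3800000 nM in this assay, at which 1 of the 3 values shown sits.

The step exchanges sulfur for selenium and adds one carbon to the acyl part at once, so the two changes cannot be separated. Going by these compounds, an acetylselanyl or a propanoylsulfanyl group at this position would separate them, while a free thiol or a carboxylic acid in place of the ethyl ester remains open.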